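Swapping 1H-tetrazol-5-yl for isopropylcarbamoyl in compound 3

A few compounds are considered here, and "the series" means these few. Any claim that something is new, unique, unknown or untested is made for them only; others in the source may bear on it.

In an ADME assay on microsomes from liver (Mus musculus) for metabolic stability (on this read-out lower numbers stand for a shorter-lived compound and higher numbers for a longer-lived compound), compound 1 `CC(C)C(Nc1nccs1)c1ccc(-c2ccc3cccc(F)c3c2)[nH]c1=O` gives 0.0733 h, while compound 2 `CC(C)C(Cc1nnn[nH]1)c1ccc(-c2ccc3cccc(F)c3c2)[nH]c1=O` gives 0.853 h, the higher of the two numbers. Compound 3 `CC(C)NC(=O)CC(c1ccc(-c2ccc3cccc(F)c3c2)[nH]c1=O)C(C)C` remains unmeasured and carries isopropylcarbamoyl in place of 1H-tetrazol-5-yl on a saturated chain carbon, two bonds along the chain from an aromatic carbon. Going by the values given here, the one measured step bearing on this change is a 12-fold higher number from compound 1 to compound 2 (1.07 log units; beyond the scatter), which is large and beyond the scatter. Among the compounds with values here, that step introduced the group now leaving, so part of that gain is expected to be lost, though no measured compound carries isopropylcarbamoyl. The expected change is a 2.8-fold lower number from compound 2 to compound 3 (0.45 log units; beyond the scatter). For compound 3 the estimate is 0.3 h, with an expected range from 0.08 h to 0.9 h.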

Compound 3, half-life: < 0.0667 h
Compound 3: no number, only a limit; the forecaster's own chance of this, stated with the estimate: 3%; middle value at least 4.4-fold (0.65 log units) from the limit.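

In this assay compound 3 gives < 0.0667 h, which is a limit of the assay and not a number. Even so, the change at this position is readable as an at least 12-fold lower number from compound 2 to compound 3 (1.10 log units; beyond the scatter), so the longer half-life of compound 2 does not carry over to isopropylcarbamoyl. The comparison with compound 1 cannot be read as an order, being an at least 1.0-fold lower number from compound 1 to compound 3 (0.04 log units; that floor lies within the scatter). On these data alone, what stays open is whether the result is specific to 1H-tetrazol-5-yl, or whether a carboxylic acid on the same chain would keep the longer half-life.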